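The source may report more compounds than this note shows. Statements on the series, on what has been measured and on what is new or still open speak of the compounds shown alone.

Compound 1 `CC(C)[C@@H]1CC[C@@H](C)C[C@@]12N(C)C(=O)[C@@H]1[C@H]3C(=O)N(C)C(=O)[C@H]3ON12` and compound 2 `Cc1cccc(N2C(=O)[C@H]3[C@H](ON4[C@@H]3C(=O)N(C)[C@@]43C[C@H](C)CC[C@H]3C(C)C)C2=O)c1` share one core and differ only at an amide-type nitrogen in a ring. In a functional assay, with a stated time of 20 min (on this read-out lower numbers stand for stronger inhibition and higher numbers for weaker inhibition), compound 1 gives 1650 ug/mL, and compound 2 gives 1880 ug/mL. The step of a 1.1-fold higher number from compound 1 to compound 2 (0.06 log units; within the scatter) lies within the scatter, so compound 2, although it carries the higher of the two numbers as read, cannot be set apart from compound 1. Compound 3 `Cc1ccc(N2C(=O)[C@H]3[C@H](ON4[C@@H]3C(=O)N(C)[C@@]43C[C@H](C)CC[C@H]3C(C)C)C2=O)c(C)c1` has not yet been measured. It differs from compound 2 by 2,4-dimethylphenyl in place of 3-methylphenyl on an amide-type nitrogen in a ring. Among the compounds with values here, the only measured step touching this position is a 1.1-fold higher number from compound 1 to compound 2 (0.06 log units; within the scatter), in which a change of group at the same nitrogen left the number within the scatter. On that basis no step beyond the scatter is expected in this assay, in either direction, so the expected step is a 1.0-fold lower number from compound 2 to compound 3 (0.02 log units; within the scatter). For compound 3 the estimate in this assay is 1800 ug/mL, with a range from 900 ug/mL to 3600 ug/mL.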

Compound 3, half-maximal inhibitory concentration: 500 ug/mL
Compound 3: middle estimate off by 3.6-fold (0.56 log units), on the high side; measured number outside the range, below it.
By their numbers in this assay, from the lowest: compound 3; then compounds 1 and 2 (each within the scatter of the next).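

At this nitrogen the aromatic group is not indifferent to change: in this assay the swap to 2,4-dimethylphenyl gives a 3.8-fold lower number from compound 2 to compound 3 (0.58 log units; beyond the scatter) and so goes beyond the scatter, whereas the earlier change from methyl to 3-methylphenyl did not. Set against the methyl group of the shared core, the same 2,4-dimethylphenyl group gives a 3.3-fold lower number from compound 1 to compound 3 (0.52 log units; beyond the scatter) in this series. Among these three compounds, then, an aromatic ring at this nitrogen does not by itself move the number, and what that ring carries does; no measured evidence accounts for the step.

As far as these compounds go, whether both methyl groups of the 2,4-dimethylphenyl group are needed remains open. Also open, from the compounds shown here alone, is what a methoxy group or a carboxylic acid on that ring, or a longer alkyl chain at this nitrogen, would give.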